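Amino in Place of Chloro on a Shared Core

This account rests on a few compounds, and the source may have more. Where it says the series, first, only, none or still open, it means among the compounds named here.

Going by the values given here, compound 2 `CCn1cc(-c2nc3ccc(Cl)cc3[nH]2)c(=O)c2cc(F)c(N3CCNCC3)cc21` is the one member of this small set that returns a number in a functional assay on HepG2 cells (Homo sapiens) for cytotoxicity, read by sulforhodamine B assay, with a stated time of 48 h (on this read-out higher numbers stand for weaker inhibition of growth and lower numbers for stronger inhibition of growth), giving 1800 nM. Compound 1 `CCn1cc(-c2nc3ccccc3[nH]2)c(=O)c2cc(F)c(N3CCNCC3)cc21` carries hydrogen where chloro sits in the compound above; in this assay compound 1 reports only a limit at > 10000 nM. Compound 3 `CCn1cc(-c2nc3ccc([N+](=O)[O-])cc3s2)c(=O)c2cc(F)c(N3CCN(C)CC3)cc21`, a nitro compound on a different core, likewise reports only a limit at > 10000 nM. Among the compounds with values here, the single measured step, an at least 5.5-fold lower number from compound 1 to compound 2 (0.74 log units; beyond the scatter), is therefore the only anchor, and it is read against (the limit of > 10000 nM in this assay, at which 2 of the 3 values shown sit).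

Compound 4 `CCn1cc(-c2nc3ccc(N)cc3[nH]2)c(=O)c2cc(F)c(N3CCNCC3)cc21` differs from compound 2 in one place: amino in place of chloro on an aromatic carbon. Within the data shown here, no measured step covers this exchange directly; the closest evidence is an at least 5.5-fold lower number from compound 1 to compound 2 (0.74 log units; beyond the scatter), and compound 4 gives up the very chloro that this step introduced. Compound 4 is therefore expected to drift back toward the limit, with a step of a 3.3-fold higher number from compound 2 to compound 4 (0.52 log units; beyond the scatter) in this assay. Compound 4 is estimated at 6000 nM in this assay, within a range of 2000 nM to 20000 nM.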

Compound 4, concentration for 50% growth inhibition: > 10000 nM
Compound 4: a limit, no number (the forecaster's own chance of this, stated with the estimate: 45%); middle value at least 1.6-fold (0.22 log units) away from the limit.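

In this assay, amino in place of chloro on this aromatic carbon gives an at least 5.5-fold higher number from compound 2 to compound 4 (0.74 log units; beyond the scatter), so the gain seen with chloro does not carry over to amino, the other group tried at this position. Compound 4 joins compound 1 at the limit of the assay, and the step between those two cannot be read, so amino and hydrogen cannot be ordered here. Of the three groups seen at this position on the shared core, only chloro brings a number into range: the limit of > 10000 nM in this assay, at which 3 of the 4 values shown sit.

The compounds shown leave open whether bromo, fluoro, methyl or methoxy at this position would behave like chloro or like amino. As far as these compounds go, how far compound 1 and compound 4 lie beyond their limit also stays unknown.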